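This account rests on a few compounds, and the source may have more. Where it says the series, first, only, none or still open, it means among the compounds named here.

In a functional assay on HL-60 cells (Homo sapiens) for antiproliferative activity, read by XTT assay, with a stated time of 72 h (on this read-out higher numbers stand for weaker inhibition and lower numbers for stronger inhibition), compound 2 `CNc1ncnc2c1c(-c1ccoc1)cn2[C@@H]1O[C@H](CO)[C@@H](O)[C@H]1O` gives only a limit of > 15000 nM. Compound 1 `CNc1ncnc2c1c(-c1ccsc1)cn2[C@@H]1O[C@H](CO)[C@@H](O)[C@H]1O` likewise gives only a limit, > 20000 nM. The step that the two limits leave unreadable from compound 1 to compound 2 therefore cannot be read. Compound 2 sits at the limit of > 15000 nM in this assay, at which 1 of the 2 values shown sits. Compound 1 sits at the limit of > 20000 nM in this assay, at which 1 of the 2 values shown sits. Compound 3 `CNc1ncnc2c1c(-c1cc3ccccc3o1)cn2[C@@H]1O[C@H](CO)[C@@H](O)[C@H]1O` differs from compound 2 by 1-benzofuran-2-yl in place of furan-3-yl on an aromatic carbon. With no readable measured step to lean on, the expected step that the limit leaves unreadable from compound 2 to compound 3 is none beyond the scatter, and a limit rather than a number is expected again. Compound 3 is thus estimated at 20000 nM, within 4000 nM to 60000 nM.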

Compound 3, half-maximal inhibitory concentration: 8950 nM
For compound 3 the middle estimate is 2.2-fold (0.35 log units) above the measured one; the measured number falls inside the stated range.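

Going by these compounds alone, with 1-benzofuran-2-yl on this aromatic carbon, compound 3 is the first compound here to give a measured number rather than a limit in this assay. Replacing thiophen-3-yl gives an at least 2.2-fold lower number from compound 1 to compound 3 (0.34 log units; beyond the scatter), and replacing furan-3-yl gives an at least 1.6-fold lower number from compound 2 to compound 3 (0.22 log units; that floor lies within the scatter); both are only floors, since compound 1 and compound 2 are limits. Among these compounds, then, only the group carrying an added six-membered aromatic ring of carbon only reaches a measurable number. On these data alone, the true size of both steps stays open, as does how a plain phenyl group or an amine would read at this position.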